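Para-methyl replaces ortho-trifluoromethyl on the pyridazinone nitrogen

The source may report more compounds than this note shows. Statements on the series, on what has been measured and on what is new or still open speak of the compounds shown alone.

Compound 1, `CNC(=O)c1cc(Oc2ccc(NC(=O)c3nn(-c4ccc(C)cc4)c(=O)cc3C)cc2F)ccn1`: 11500 nM
Compound 2, `CNC(=O)c1cc(Oc2ccc(NC(=O)c3nn(-c4ccccc4F)c(=O)cc3C)cc2F)ccn1`: > 40000 nM
Compound 3, `Cc1cc(=O)n(-c2ccccc2C(F)(F)F)nc1C(=O)Nc1ccc(Oc2ncnc3ccsc23)cc1`: 8850 nM

The read-out is a functional assay on A549 cells (Homo sapiens) for cytotoxicity, read by MTT assay, with a stated time of 72 h; a higher number here means a weaker inhibitor, a lower number a stronger inhibitor. Compound 1 gives 11500 nM and compound 3 gives 8850 nM, two numbers that lie within the usual scatter of each other, so neither can be called the stronger. Compound 2 sits at the limit of > 40000 nM in this assay, at which 1 of the 3 values shown sits, a limit rather than a number.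

The unmeasured compound 4, `Cc1ccc(-n2nc(C(=O)Nc3ccc(Oc4ncnc5ccsc45)cc3)c(C)cc2=O)cc1`, differs from compound 3 by 4-methylphenyl in place of 2-(trifluoromethyl)phenyl on an aromatic nitrogen. Among the compounds with values here, one measured step bears on it: an at least 3.4-fold higher number from compound 1 to compound 2 (0.54 log units; beyond the scatter). There, exchanging 4-methylphenyl for a phenyl carrying a single ortho substituent raised the number, at least modestly. Compound 4 runs in the opposite direction, replacing an ortho-substituted phenyl with 4-methylphenyl, though on a different core and with trifluoromethyl rather than fluorine leaving. A modest fall in the number is therefore expected, and compound 4 is estimated at 4500 nM, within 1500 nM to 14000 nM, meaning an expected step of a 2.0-fold lower number from compound 3 to compound 4 (0.29 log units; within the scatter).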

Compound 4, half-maximal inhibitory concentration: 11500 nM
Estimate against measurement, compound 4: 2.6-fold (0.41 log units) below; the range from low to high includes it.
By their numbers in this assay, from the lowest: compounds 3, 1 and 4 (each within the scatter of the next). At a limit, above all of these: compound 2.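

In this assay the exchange gives a 1.3-fold higher number from compound 3 to compound 4 (0.11 log units; within the scatter), so on this core 4-methylphenyl and 2-(trifluoromethyl)phenyl cannot be told apart on the aromatic nitrogen. Within the data shown here, the one earlier step at this position, an at least 3.4-fold higher number from compound 1 to compound 2 (0.54 log units; beyond the scatter), came on another core and with 2-fluorophenyl, and it showed that a change here can matter; the new pair shows that such a change need not, so that earlier step does not carry over to every core or every substituent. Nothing measured here accounts for the contrast between the two steps.

Going by these compounds, whether a phenyl carrying an amine or a carboxylic acid on this nitrogen would move the number beyond the scatter remains open. So does whether 2-fluorophenyl on the core of compound 3 would behave as it does on the core of compound 2.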